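The source may hold more compounds than are shown below. What is called first, only, known or untested is meant among the compounds shown, and "the series" means these compounds.

Measured compounds in an ADME assay on MT2 cells (Homo sapiens) for cytotoxicity, read by XTT assay, with a stated time of 4 days; on this read-out higher numbers stand for lower toxicity in this test and lower numbers for higher toxicity in this test:
- compound 1, `CCOC(=O)/C(C#N)=C/c1cc(C)n(-c2cccc(-c3nnn[nH]3)c2)c1C`, gives 76800 nM
- compound 2, `Cc1cc(/C=C2\SC(=S)N(c3cccc(C(F)(F)F)c3)C2=O)c(C)n1-c1cccc(-c2nnn[nH]2)c1`, gives 15800 nM
- compound 3, `Cc1cc(/C=C2\SC(=S)N(c3cccc(O)c3)C2=O)c(C)n1-c1cccc(-c2nnn[nH]2)c1`, gives 35600 nM

Among these three, compound 3 stands second highest in this assay: compound 1 sits higher and compound 2 sits lower, and both gaps are beyond the scatter. Compound 4, `COc1ccc(N2C(=O)/C(=C/c3cc(C)n(-c4cccc(-c5nnn[nH]5)c4)c3C)SC2=S)cc1`, differs from compound 3 in one place: 4-methoxyphenyl in place of 3-hydroxyphenyl on an amide-type nitrogen in a ring. Going by the values given here, the only measured step that touches the same place is the one in which the group carried by the ring on the amide-type nitrogen was exchanged, giving a 2.3-fold higher number from compound 2 to compound 3 (0.35 log units; beyond the scatter). That step shows that changes at this place can shift the number modestly, but it compares a trifluoromethyl with a hydroxy group, neither of which is the 4-methoxyphenyl that enters here, so it offers only a loose guide. Compound 1 has a different core and does not bear on this change. The step of a 1.2-fold lower number from compound 3 to compound 4 (0.07 log units; within the scatter) is therefore expected to stay small, within the scatter, with no firm direction. Compound 4 is estimated at 30000 nM, with a range from 12000 nM to 75000 nM.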

Compound 4, half-maximal cytotoxic concentration: 87000 nM
The estimate for compound 4 lay 2.9-fold (0.46 log units) below the measured number; measured number above the stated range.
By their numbers in this assay, from the lowest: compound 2; then compound 3; then compounds 1 and 4 (each within the scatter of the next).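

In this assay, going by these compounds alone, the group on the amide-type nitrogen in the ring moves the number further than the only earlier step at this place suggested, and 3-hydroxyphenyl is not the top of the range here (a step of a 2.4-fold higher number from compound 3 to compound 4 (0.39 log units; beyond the scatter)). Taken across the two ends of the series at this place, the shift is larger still (a step of a 5.5-fold higher number from compound 2 to compound 4 (0.74 log units; beyond the scatter)), which means higher numbers and lower toxicity in this test with 4-methoxyphenyl than with 3-(trifluoromethyl)phenyl. Nothing measured here gives a reason for these shifts.

Going by these compounds, the swap from compound 3 to compound 4 changes both the group on the phenyl ring and its numbered position, so the effect of each alone stays open; 4-hydroxyphenyl or 3-methoxyphenyl would separate them. On these data alone, how an amine or a carboxylic acid on that phenyl ring would read also remains unknown.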